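Shifting a Methoxy Position: Expected Cytotoxicity of Compound 3

The source may report more compounds than this note shows. Statements on the series, on what has been measured and on what is new or still open speak of the compounds shown alone.

Compound 1 `COc1ccc(-c2c(-c3ccccc3)oc3cc(OC)ccc23)c(O)c1`: 28900 nM
Compound 2 `COc1cccc(-c2oc3cc(O)ccc3c2-c2ccc(O)cc2O)c1`: 29900 nM

Both compounds were tested in a functional assay on HeLa cells (Homo sapiens) for cytotoxicity, read by MTT assay, with a stated time of 48 h; a lower number here means a stronger inhibitor, a higher number a weaker inhibitor. Compound 2 has the highest of the two numbers, but its gap to compound 1 lies within the scatter, so the two cannot be told apart. Compound 3 `COc1ccc(-c2oc3cc(O)ccc3c2-c2ccc(O)cc2O)cc1` is not yet measured and differs from compound 2 in one place: 4-methoxyphenyl in place of 3-methoxyphenyl on an aromatic carbon. Going by the values given here, no step between measured compounds is known, so nothing shows how large such a change is. The step of a 1.1-fold lower number from compound 2 to compound 3 (0.03 log units; within the scatter) is expected to stay within the scatter. For compound 3 the estimated value is 28000 nM, with a range from 10000 nM to 80000 nM.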

Compound 3, half-maximal inhibitory concentration: 13700 nM
Estimate against measurement, compound 3: 2.0-fold (0.31 log units) above; measured number inside the range.
By their numbers in this assay, from the lowest: compound 3; then compounds 1 and 2 (each within the scatter of the next).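

Replacing 3-methoxyphenyl with 4-methoxyphenyl gives a 2.2-fold lower number from compound 2 to compound 3 (0.34 log units; beyond the scatter) in this assay. This is a modest step, but it shows that this place on the shared core can respond to where the methoxy group sits on the phenyl ring, even though the two groups have the same atoms. Nothing available explains the difference.

Going by these compounds, whether an amine or a carboxylic acid on that phenyl ring would lower the number further remains open. So does whether the same methoxy shift would matter on the core of compound 1.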